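Replacing 3,5-dichlorophenyl with 3-fluorophenyl: notes on compound 4

A few compounds are considered here, and "the series" means these few. Any claim that something is new, unique, unknown or untested is made for them only; others in the source may bear on it.

In a toxicity assay on HUVEC cells (Homo sapiens) for inhibition (on this read-out higher numbers stand for weaker inhibition of growth and lower numbers for stronger inhibition of growth), compound 1 `Cc1nc(-c2ccccc2)c(C(=O)N2CCN(c3cccc(Cl)c3)CC2)o1` gives 0.463 ug/mL, compound 2 `Cc1nc(-c2ccccc2)c(C(=O)N2CCN(c3cccc(C)c3C)CC2)o1` gives 0.38 ug/mL and compound 3 `Cc1nc(-c2ccccc2)c(C(=O)N2CCN(c3cc(Cl)cc(Cl)c3)CC2)o1` gives 0.191 ug/mL. The data show a 2.0-fold lower number from compound 2 to compound 3 (0.30 log units; within the scatter) and a 2.4-fold lower number from compound 1 to compound 3 (0.38 log units; beyond the scatter), so compound 3 separates from only one of the other two. The remaining step, a 1.2-fold lower number from compound 1 to compound 2 (0.09 log units; within the scatter), is also small.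

Compound 4 `Cc1nc(-c2ccccc2)c(C(=O)N2CCN(c3cccc(F)c3)CC2)o1` follows from compound 3 through (3-fluorophenyl in place of 3,5-dichlorophenyl on an amine nitrogen in a ring), that is, 3-fluorophenyl in place of 3,5-dichlorophenyl on an amine nitrogen in a ring. Among the compounds with values here, compound 1, with its 3-chlorophenyl, is the closest measured comparison, though no measured step covers fluoro against chloro. Read in reverse, the modest step of a 2.4-fold lower number from compound 1 to compound 3 (0.38 log units; beyond the scatter) suggests that losing the second chloro raises the number by a similar amount. The expected change is a 2.4-fold higher number from compound 3 to compound 4 (0.37 log units; beyond the scatter), a modest rise in this assay. The estimate for compound 4 is 0.45 ug/mL, with an expected range of 0.2 ug/mL to 1 ug/mL.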

Compound 4, concentration for 50% growth inhibition: 1.05 ug/mL
Compound 4: middle estimate off by 2.3-fold (0.37 log units), on the low side; the measured number lies above the stated range.
By their numbers in this assay, from the lowest: compounds 3, 2 and 1 (each within the scatter of the next, the first and the last beyond it); then compound 4.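

In this assay, within the data shown here, the step from chloro to fluoro on an aromatic carbon (a 2.3-fold higher number from compound 1 to compound 4 (0.36 log units; beyond the scatter)) shows that the number responds to the identity of this single halogen, which no earlier step covered. The two other steps (a 2.8-fold higher number from compound 2 to compound 4 (0.44 log units; beyond the scatter); a 5.5-fold higher number from compound 3 to compound 4 (0.74 log units; beyond the scatter)) run in the same direction, so 3-fluorophenyl gives a higher number than each of the three earlier groups on the ring nitrogen, and its replacement of 3,5-dichlorophenyl is the largest step in the series. Nothing measured here accounts for the difference between fluoro and chloro.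

Still open, on these data alone, is whether a second fluoro would lower the number as a second chloro did. Also open, as far as these compounds go, is where an unsubstituted phenyl, a methoxy group or a nitrile on this aromatic ring would fall relative to compound 4.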